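Cytotoxicity notes on a sulfonyl-benzimidazole pyrazole series

The compounds below may be only part of what the source reports. "The series", "measured", "known", "first", "only" and "open" are said of these compounds alone.

Measured so far:
compound 1 `O=S(=O)(c1ccc(Br)cc1)n1c(-c2cn(-c3ccccc3)nc2-c2ccc(F)cc2)nc2ccccc21`: 239000 nM
compound 2 `O=S(=O)(c1ccc(C(F)(F)F)cc1)n1c(-c2cn(-c3ccccc3)nc2-c2ccc(F)cc2)nc2ccccc21`: 241000 nM
compound 3 `O=S(=O)(c1ccc(Br)cc1)n1c(-c2cn(-c3ccccc3)nc2-c2ccc(C(F)(F)F)cc2)nc2ccccc21`: 185000 nM

All three were run in an ADME assay on HEK-293T cells (Homo sapiens) for cytotoxicity, read by MTT assay, with a stated time of 24 h; a lower number here means that less compound is tolerated, a higher number that more compound is tolerated. Compound 1 gives 239000 nM, and compound 2 gives 241000 nM; the change between them is trifluoromethyl in place of bromo on an aromatic carbon, and the step is a 1.0-fold higher number from compound 1 to compound 2 (0.00 log units; within the scatter). Compound 3 gives 185000 nM; its core differs from that of compound 1 by trifluoromethyl in place of fluoro on an aromatic carbon, with the step of a 1.3-fold lower number from compound 1 to compound 3 (0.11 log units; within the scatter). None of the three steps leaves the scatter.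

Compound 4 `O=S(=O)(c1ccc(C(F)(F)F)cc1)n1c(-c2cn(-c3ccccc3)nc2-c2ccc(C(F)(F)F)cc2)nc2ccccc21` has not yet been measured in this assay. It differs from compound 3 by trifluoromethyl in place of bromo on an aromatic carbon, the same change as that from compound 1 to compound 2, at the same place on the ring. The step from compound 3 to compound 4 is expected to be no change at the digits printed from compound 3 to compound 4 (within the scatter), resting on the flat step a 1.0-fold higher number from compound 1 to compound 2 (0.00 log units; within the scatter). Compound 4 is therefore estimated at 185000 nM, within 115000 nM to 290000 nM.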

Compound 4, half-maximal cytotoxic concentration: 63200 nM
Compound 4: the middle estimate sits 2.9-fold (0.47 log units) above what was measured, and the stated range ends above it.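

In this assay, trifluoromethyl in place of bromo gives a 2.9-fold lower number from compound 3 to compound 4 (0.47 log units; beyond the scatter), which does not match the same change on the core of compound 1: the same change on two cores in this assay, a 1.0-fold higher number (0.00 log units; within the scatter) from compound 1 to compound 2 and a 2.9-fold lower number (0.47 log units; beyond the scatter) from compound 3 to compound 4, 3.0-fold (0.47 log units) apart, beyond the scatter of two such steps. Trifluoromethyl in place of fluoro gives a 3.8-fold lower number from compound 2 to compound 4 (0.58 log units; beyond the scatter), and this step also differs from its earlier counterpart: the same change on two cores in this assay, a 1.3-fold lower number (0.11 log units; within the scatter) from compound 1 to compound 3 and a 3.8-fold lower number (0.58 log units; beyond the scatter) from compound 2 to compound 4, 3.0-fold (0.47 log units) apart, beyond the scatter of two such steps. Both gaps rest on the same four compounds and so show one failure of additivity, in which neither change carries unaltered from one core to the other, but they do not show its cause or whether it extends beyond these compounds.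

From the compounds shown here alone, it remains open whether other groups at these two places, such as an amine or a carboxylic acid, would behave the same way.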